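Thiazolyl for Pyrimidinyl on the Piperazine Nitrogen

The source may hold more compounds than are shown below. What is called first, only, known or untested is meant among the compounds shown, and "the series" means these compounds.

Compound 2 `CCO/N=C(\CCN1CCN(c2ncccn2)CC1)c1ccccc1` is the weaker of the two measured compounds: in a functional assay on HEK293 cells with D(4) dopamine receptor (Homo sapiens) as the target, read by FLIPR (on this read-out higher numbers stand for an effect only at larger amounts of compound and lower numbers for an effect already at smaller amounts), compound 2 gives 615 nM, the highest of the two numbers, whereas compound 1 `CCO/N=C(\CCN1CCN(c2ccccc2)CC1)c1ccccc1` gives 109 nM. Among the measured compounds shown here, the only measured step, a 5.6-fold higher number from compound 1 to compound 2 (0.75 log units; beyond the scatter), shows that swapping the aromatic group on the ring nitrogen moves the number by a modest but real amount.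

Compound 3 `CCO/N=C(\CCN1CCN(c2nccs2)CC1)c1ccccc1` is not yet measured. It differs from compound 2 by 1,3-thiazol-2-yl in place of pyrimidin-2-yl on an amine nitrogen in a ring. For the measured compounds named here, no measured pair reports this exact exchange, so only the step from compound 1 to compound 2 bears on it, and that step was modest. A change of the aromatic group at this position can therefore be expected to shift the number by a similar or smaller amount, and a move back toward the value of compound 1 seems somewhat more likely than a further rise, though a step within the scatter is also plausible. For compound 3 the estimated value in this assay is 350 nM, with a range from 120 nM to 1200 nM, which corresponds to an expected step of a 1.8-fold lower number from compound 2 to compound 3 (0.24 log units; within the scatter).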

Compound 3, half-maximal effective concentration: 81.8 nM
The estimate for compound 3 lay 4.3-fold (0.63 log units) above the measured number; the measured number lies below the stated range.
By their numbers in this assay, from the lowest: compounds 3 and 1 (each within the scatter of the next); then compound 2.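

The pyrimidin-2-yl group of compound 2 now stands apart at this position, with a 7.5-fold lower number from compound 2 to compound 3 (0.88 log units; beyond the scatter) in this assay, while the exchange of phenyl for 1,3-thiazol-2-yl gives a 1.3-fold lower number from compound 1 to compound 3 (0.12 log units; within the scatter). An aromatic group on the ring nitrogen therefore need not be six-membered for the number to stay level with that of compound 1, and carrying two hetero atoms in the ring does not by itself go with a higher number, as 1,3-thiazol-2-yl and pyrimidin-2-yl both carry two. Why these two rings with the same count of hetero atoms and hydrogen-bond acceptors part so clearly cannot be said from anything available here.

The three compounds leave open whether a pyridin-2-yl group, with a single ring nitrogen, would fall with compound 3 or with compound 2, and whether a plain methyl group on this nitrogen would keep any of the effect seen with the aromatic groups. They also leave open whether the level reached with 1,3-thiazol-2-yl would hold if the ethyl group at the other end of the molecule gave way to a longer chain.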